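The source may report more compounds than this note shows. Statements on the series, on what has been measured and on what is new or still open speak of the compounds shown alone.

Series notes on the shared core. Compound 1 `O=C(Nc1ccc(Cl)cc1CN1C(=O)c2ccccc2C1=O)c1ccccc1` is the reference. In an assay on CHO cells for positive allosteric modulation of metabotropic glutamate receptor 5 (Rattus norvegicus), read by FLIPR (a lower number here means that less compound is needed, a higher number that more compound is needed for the effect), compound 1 gives only a limit, < 1000 nM. Compound 2 `O=C(Nc1ccc(Cl)cc1CN1C(=O)c2ccccc2C1=O)c1ccccc1C(F)(F)F` carries trifluoromethyl in place of hydrogen on an aromatic carbon. In this assay compound 2 likewise gives only a limit, < 1000 nM. The step from compound 1 to compound 2 therefore cannot be sized: a step that the two limits leave unreadable from compound 1 to compound 2. The whole evidence is the limit of < 1000 nM in this assay, at which 2 of the 2 values shown sit. Compound 3 `O=C(Nc1ccc(Cl)cc1CN1C(=O)c2ccccc2C1=O)c1ccccc1[N+](=O)[O-]` differs from compound 1 by nitro in place of hydrogen on an aromatic carbon. For the measured compounds named here, the one measured step that bears on this change, the trifluoromethyl substitution, has no readable size, so neither direction nor magnitude can be taken from it beyond the fact that both compounds stay at the limit. Compound 3 is expected to remain in the same region, an estimated step that the limit leaves unreadable from compound 1 to compound 3. Compound 3 is estimated at 400 nM in this assay, with an expected range from 80 nM to 2000 nM.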

Compound 3, half-maximal effective concentration: < 1000 nM
Compound 3: no number, only a limit (the forecaster's own chance of this, stated with the estimate: 65%); the middle value is on the limit's open side.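

In this assay, for the compounds shown here, compound 1, compound 2 and compound 3 all give only a limit, so no step among them can be read: the limit of < 1000 nM in this assay, at which 3 of the 3 values shown sit. The compounds shown leave open whether hydrogen, trifluoromethyl and nitro on this aromatic carbon differ at all in the concentration needed.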